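A methoxy group on the most active of three compounds

The compounds below may be only part of what the source reports. "The series", "measured", "known", "first", "only" and "open" are said of these compounds alone.

Among the measured compounds shown here, in a functional assay on K562 cells (Homo sapiens) for inhibition, read by trypan blue exclusion, with a stated time of 24 h, tested at 10 uM (a lower number here means less inhibition of growth, a higher number more inhibition of growth at the concentration tested), compound 1 `NC(=O)c1ccccc1NC(=O)COc1ccccc1` gives 57.4%, the highest figure among the compounds measured so far. Compound 2 `Cc1ccccc1OCC(=O)Nc1ccccc1C(N)=O` gives 19.7%. Compound 3 `Cc1ccc(OCC(=O)Nc2ccccc2C(N)=O)cc1` returns only a limit of the assay, < 10%.

Compound 4 `COc1ccc(NC(=O)COc2ccccc2)c(C(N)=O)c1` differs from compound 1 in one place, with methoxy in place of hydrogen on an aromatic carbon. The new group stands meta to a carbamoyl group and para to a large group.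

The closest evidence comes from the two methyl additions that lead to compound 2 and compound 3. The first is a number 37.7 percentage points lower from compound 1 to compound 2 (beyond the scatter), and the second is a number at least 47.4 percentage points lower from compound 1 to compound 3 (beyond the scatter). Both steps are large and point the same way, so each addition to compound 1 measured so far has come with less growth inhibition. For the measured compounds named here, those methyl groups sit on the other aromatic ring, however, and no measured compound carries an added group on the ring that holds the carbamoyl group. They are therefore only a loose guide, and a fall of more modest size seems likely.

In this assay, the expected change is a number 22.4 percentage points lower from compound 1 to compound 4 (beyond the scatter). Compound 4 is estimated at 35%, with an expected range of 12% to 62%.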

Compound 4, percent growth inhibition at one concentration: 85.3%
Beside the measured number, compound 4's estimate is 50.3 percentage points below it; the measured number lies above the stated range.
By their numbers in this assay, from the lowest: compound 2; then compound 1; then compound 4. At a limit, below all of these: compound 3.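

Replacing a hydrogen with methoxy on an aromatic carbon gives, in this assay, a number 27.9 percentage points higher from compound 1 to compound 4 (beyond the scatter) and so shows that an addition to compound 1 can raise growth inhibition as well as lower it. The two methyl additions on the other aromatic ring, which gave compound 2 and compound 3, both went the opposite way, so compound 4 goes against the fall seen with every earlier addition, and no single rule for additions to compound 1 holds across these compounds. This position, meta to a carbamoyl group and para to a large group, is thus the first place on the core of compound 1 shown to take an added group with a gain in this read-out, although nothing shown here accounts for that gain.

As far as these compounds go, it remains open whether the gain is particular to methoxy or would also appear with a hydroxyl group, a chlorine atom or an amine at the same position. Also open, from the compounds shown here alone, is whether methoxy at this position would still raise the figure in compounds carrying the methyl groups of compound 2 or compound 3.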